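Cytotoxicity notes on an anilide series: compound 3 to compound 4

The source may report more compounds than this note shows. Statements on the series, on what has been measured and on what is new or still open speak of the compounds shown alone.

Measured compounds:
compound 1 `O=C(CCSc1nnc(-c2ccncc2)s1)Nc1ccc(Cl)cc1` — 7260 nM
compound 2 `CC(Sc1nnc(-c2ccncc2)s1)C(=O)Nc1ccccc1` — > 50000 nM
compound 3 `O=C(CCSc1nnc(-c2ccncc2)s1)Nc1ccccc1` — > 50000 nM

In an ADME assay on HepG2 cells (Homo sapiens) for cytotoxicity, with a stated time of 3 days (on this read-out lower numbers stand for higher toxicity in this test and higher numbers for lower toxicity in this test), compound 3 reaches only a limit, > 50000 nM, with no number inside the range of the test. The same holds for compound 2, whose value > 50000 nM is likewise a limit. Within the data shown here, compound 1 is the one member with a number, 7260 nM in this assay; a feature of the set is the limit of > 50000 nM in this assay, at which 2 of the 3 values shown sit.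

The unmeasured compound 4 `O=C(CCSc1nnc(-c2ccncc2)s1)Nc1c(Cl)cccc1Cl` differs from compound 3 by 2,6-dichlorophenyl in place of phenyl on an amide-type nitrogen. Among the measured compounds shown here, the only measured step that touches this part of the molecule is an at least 6.8-fold higher number from compound 1 to compound 3 (0.83 log units; beyond the scatter), which runs the other way: removing a chloro on the aromatic ring pushed the number up to the limit. For the measured compounds named here, putting two chloro substituents back onto the same ring, though in a different arrangement, therefore leans toward a lower number in this assay, but the single comparison and the limit at compound 3 leave the size open.

Compound 4 is expected to come in at 20000 nM, with a plausible range from 5000 nM to 60000 nM. The expected step from compound 3 to compound 4 is an at least 2.5-fold lower number from compound 3 to compound 4 (0.39 log units; beyond the scatter), and a result that again stops at the limit cannot be excluded.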

Compound 4, half-maximal cytotoxic concentration: 12600 nM
Estimate against measurement, compound 4: 1.6-fold (0.20 log units) above; measured number inside the range.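

In this assay, an at least 3.9-fold lower number from compound 3 to compound 4 (0.59 log units; beyond the scatter), so compound 1 is no longer the only anilide of this chain that gives a number inside the range of the test; a chlorinated ring on the amide-type nitrogen now goes with a lower number in both compounds that carry one. The arrangement of chloro on the ring adds no readable difference, since a 1.7-fold higher number from compound 1 to compound 4 (0.24 log units; within the scatter), and 2,6-dichlorophenyl and 4-chlorophenyl cannot be told apart in this test. Both steps away from phenyl remain bounds rather than sizes because compound 3 stands at a limit, not a number: the limit of > 50000 nM in this assay, at which 2 of the 4 values shown sit.

The compounds shown leave open whether the drop belongs to chloro itself or would also appear with another group on the ring, such as methoxy, fluoro or a carboxylic acid. They also leave open whether chloro on the ring would lower the number on the branched chain of compound 2, or with a longer chain between the sulfur and the carbonyl.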